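Semicarbazone series: expected dose for hydroxyphenyl analogue

A few compounds are considered here, and "the series" means these few. Any claim that something is new, unique, unknown or untested is made for them only; others in the source may bear on it.

Measured so far:
compound 1, `COc1ccc(/C=N/NC(=O)Nc2cccc3ccccc23)cc1OC`, 100 mg/kg
compound 2, `COc1cccc(/C=N/NC(=O)Nc2cccc3ccccc23)c1`, 100 mg/kg
compound 3, `COc1ccc(OC)c(/C=N/NC(=O)Nc2cccc3ccccc23)c1`, 300 mg/kg

In a functional assay on the whole organism (strain Swiss albino) with Mus musculus as the target, with a stated time of 0.5 h (on this read-out higher numbers stand for an effect only at larger amounts of compound and lower numbers for an effect already at smaller amounts), compound 2 gives 100 mg/kg. Compound 2 stands level with compound 1 at the digits recorded, and the two together sit at the lowest number of the three; the gap to compound 3 is the largest, a 3.0-fold higher number from compound 2 to compound 3 (0.48 log units; beyond the scatter).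

The next compound, compound 4, `O=C(N/N=C/c1ccccc1O)Nc1cccc2ccccc12`, has not yet been tested. Its change from compound 2 is 2-hydroxyphenyl in place of 3-methoxyphenyl on a carbon with a double bond to nitrogen.

Within the data shown here, two measured steps bear on the change, though neither covers it directly. Removing a methoxy on an aromatic carbon gave no change at the digits printed from compound 1 to compound 2 (within the scatter), while adding one gave a 3.0-fold higher number from compound 2 to compound 3 (0.48 log units; beyond the scatter). Both concern methoxy only; nothing measured here shows what a hydroxyl on the aryl ring does, nor what the loss of the methoxy group of compound 2 without any replacement would do. The series therefore suggests that small changes on this ring move the number by no more than a modest amount, in either direction.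

For compound 4 a step of no change at the digits printed from compound 2 to compound 4 (within the scatter) is expected, that is, no change beyond the scatter. The estimate for compound 4 in this assay is 100 mg/kg, with a range from 50 mg/kg to 300 mg/kg.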

Compound 4, minimum effective dose: 300 mg/kg
For compound 4 the middle estimate is 3.0-fold (0.48 log units) below the measured one, within the range that was stated.
By their numbers in this assay, from the lowest: compounds 1 and 2 (each within the scatter of the next); then compounds 3 and 4 (each within the scatter of the next).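

In this assay, 2-hydroxyphenyl in place of 3-methoxyphenyl on the carbon with a double bond to nitrogen gives a 3.0-fold higher number from compound 2 to compound 4 (0.48 log units; beyond the scatter), so a step beyond the scatter at this position is no longer tied to adding a methoxy, as in a 3.0-fold higher number from compound 2 to compound 3 (0.48 log units; beyond the scatter). The entering group has 1 hydrogen-bond donor and the leaving group has 0, but this count changes together with the identity of the substituent and its place on the ring, so this single step cannot assign the higher number to any one of them. No measurement at hand explains the step from compound 2 to compound 4.

Open, from the compounds shown here alone, is how phenyl with no substituent would read in this assay, which would give a reference for both 2-hydroxyphenyl and 3-methoxyphenyl. Also open, going by these compounds, is whether an amine or a carboxylic acid on this ring would stay level with compound 2 at 100 mg/kg or give a number that differs beyond the scatter in either direction.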